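A Methyl Shifted Along the Dienyl Side Chain

A few compounds are considered here, and "the series" means these few. Any claim that something is new, unique, unknown or untested is made for them only; others in the source may bear on it.

In a functional assay on the whole organism with Canis familiaris (Canis lupus familiaris) as the target (a lower number here means that less compound is needed, a higher number that more compound is needed for the effect), compound 1 `C/C=C(C)\C=C\[C@](C)(O)C/C=C/[C@H]1[C@H](O)CC(=O)[C@@H]1CC/C=C\CCC(=O)OC` gives 0.000016 mg/kg while compound 3 `C=C(C)/C=C/[C@](C)(O)C/C=C/[C@H]1[C@H](O)CC(=O)[C@@H]1CC/C=C\CCC(=O)OC` gives 0.00002 mg/kg and compound 2 `C=C/C(C)=C/[C@](C)(O)C/C=C/[C@H]1[C@H](O)CC(=O)[C@@H]1CC/C=C\CCC(=O)OC` gives 0.00071 mg/kg on the same shared core. Compound 3 thus sits at the low end of these numbers, level with compound 1. The data show a 1.3-fold higher number from compound 1 to compound 3 (0.10 log units; within the scatter) as a gap that means little, and a 36-fold lower number from compound 2 to compound 3 (1.55 log units; beyond the scatter) as a large one.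

In compound 4 `C/C=C/C=C/[C@](C)(O)C/C=C/[C@H]1[C@H](O)CC(=O)[C@@H]1CC/C=C\CCC(=O)OC` prop-1-en-1-yl replaces 1-methylethenyl on a double-bonded chain carbon bound to a double-bonded chain carbon, and prop-1-en-1-yl in place of 1-methylethenyl on a double-bonded chain carbon bound to a double-bonded chain carbon gives the count of that change. For the measured compounds named here, two measured steps bear on it. Compound 1 carries the same chain-end extension that compound 4 gains, and a 1.3-fold higher number from compound 1 to compound 3 (0.10 log units; within the scatter) suggests that this extension alone should matter little. Compound 2 shows that the placement of the methyl can matter, with a 44-fold higher number from compound 1 to compound 2 (1.65 log units; beyond the scatter) as its cost. Going by the values given here, no measured compound lacks that methyl entirely, so the uncertainty leans towards higher numbers. The expected change is small, a 1.8-fold higher number from compound 3 to compound 4 (0.24 log units; within the scatter) as the estimated step, probably within the scatter. For compound 4 the estimated value is 0.000035 mg/kg with an expected range from 0.00001 mg/kg to 0.0003 mg/kg in this assay.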

Compound 4, dose for half-maximal effect: 0.00003 mg/kg
Estimate against measurement, compound 4: 1.2-fold (0.07 log units) above; low and high end bracket the measured number.
By their numbers in this assay, from the lowest: compounds 1, 3 and 4 (each within the scatter of the next); then compound 2.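

With prop-1-en-1-yl on a double-bonded chain carbon bound to a double-bonded chain carbon, compound 4 carries the penta-1,3-dien-1-yl chain, which has no methyl branch, yet in this assay it shows a 1.5-fold higher number from compound 3 to compound 4 (0.18 log units; within the scatter) and a 1.9-fold higher number from compound 1 to compound 4 (0.27 log units; within the scatter), so among these compounds a methyl branch on this chain is not required for a low number. The large step to compound 2 remains, a 24-fold lower number from compound 2 to compound 4 (1.37 log units; beyond the scatter), which leaves compound 2, with its 2-methylbuta-1,3-dien-1-yl chain, as the only one of the four apart from the others, while compounds 1, 3 and 4 stay within the scatter of one another. No measured evidence accounts for this difference in the compounds shown.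

The compounds shown leave open whether the double bonds of this chain matter, as every chain here is a dienyl one, and a saturated pentyl chain or a phenyl group in its place would test that. They also leave open how far the chain can grow on a double-bonded chain carbon, for instance with a longer chain such as but-1-en-1-yl in place of prop-1-en-1-yl.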